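The source may report more compounds than this note shows. Statements on the series, on what has been measured and on what is new or still open speak of the compounds shown alone.

Three compounds have been measured in a functional assay on isolated protein for inhibition of Glucose-dependent insulinotropic receptor (Rattus norvegicus), read by HTRF and cAMP accumulation; a lower number here means that less compound is needed, a higher number that more compound is needed for the effect:
compound 1, `Cc1nc(S(C)(=O)=O)ccc1Oc1ncnc(OC2CCN(C(=O)OC(C)(C)C(F)(F)F)CC2)c1F`: 47.2 nM
compound 2, `Cc1nc(S(C)(=O)=O)ccc1Oc1ncnc(OC2CCN(C(=S)OC3(C)CC3)CC2)c1F`: 48.8 nM
compound 3, `Cc1nc(S(C)(=O)=O)ccc1Oc1ncnc(OC2CCN(C(=O)C3(F)CCC3)CC2)c1F`: 123 nM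

Compound 1 stands at the low end of these three numbers; compound 2 sits alongside it, with a 1.0-fold higher number from compound 1 to compound 2 (0.01 log units; within the scatter), while compound 3 is further off, with a 2.6-fold higher number from compound 1 to compound 3 (0.42 log units; beyond the scatter). Compound 4, `Cc1nc(S(C)(=O)=O)ccc1Oc1ncnc(OC2CCN(C(=O)C3CCCC3)CC2)c1F`, differs from compound 1 in a single place: cyclopentyl in place of 1-methyl-1-(trifluoromethyl)ethoxy on a carbonyl carbon. Going by the values given here, the step that bears on this change is the one from compound 1 to compound 3, where a four-membered carbon ring carrying one fluorine likewise replaced the 1-methyl-1-(trifluoromethyl)ethoxy on the carbonyl carbon and the number rose modestly. A step of similar size and direction is expected here. Compound 4 is therefore estimated at 105 nM, with a range from 50 nM to 230 nM. This is expected to correspond to a 2.2-fold higher number from compound 1 to compound 4 (0.35 log units; beyond the scatter).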

Compound 4, half-maximal effective concentration: 407 nM
Beside the measured number, compound 4's estimate is 3.9-fold (0.59 log units) below it; the whole stated range lies below it.
By their numbers in this assay, from the lowest: compounds 1 and 2 (each within the scatter of the next); then compound 3; then compound 4.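

Putting cyclopentyl on this carbonyl carbon costs far more than the earlier change did, with an 8.6-fold higher number from compound 1 to compound 4 (0.94 log units; beyond the scatter) as the step. A carbon ring there does not by itself set the number: a 3.3-fold higher number from compound 3 to compound 4 (0.52 log units; beyond the scatter) separates two ring-bearing compounds, and an 8.3-fold higher number from compound 2 to compound 4 (0.92 log units; beyond the scatter) shows that the sulfur-containing compound with its three-membered ring also keeps a clear lead. No measured evidence offered here explains these gaps.

Compound 3 differs from compound 4 in both ring size and fluorine, so the two cannot be separated. A plain cyclobutyl group would help to tell them apart, while a cyclopentyl carrying an amine remains an open case.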